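A few compounds are considered here, and "the series" means these few. Any claim that something is new, unique, unknown or untested is made for them only; others in the source may bear on it.

Measured so far, all in a functional assay on OVCAR-3 cells (Homo sapiens) for cytotoxicity, read by sulforhodamine B assay, with a stated time of 48 h, tested at 0.01 uM; on this read-out higher numbers stand for a weaker effect at the one concentration tested and lower numbers for a stronger effect:

Compound 1 `COc1ccc(-c2cc(/C=C/C(=O)c3ccc(N)cc3)[nH]n2)cc1`: 104%
Compound 2 `COc1ccc(-c2cc(/C=C/C(=O)c3ccc(N)cc3)[nH]n2)cc1OC`: 106%
Compound 3 `COc1cc(C(=O)/C=C/c2cc(-c3cc(OC)c(OC)c(OC)c3)n[nH]2)cc(OC)c1OC`: 107%

Compound 2 and compound 1 differ in one place, (hydrogen in place of methoxy on an aromatic carbon). The step that this made in this assay was a number 2 percentage points lower from compound 2 to compound 1 (within the scatter), so the two numbers cannot be told apart. Compound 3 carries a different core; the difference between the two cores is not broken down here. Its value lies nearest to compound 2 and furthest from compound 1, but both gaps fall within the scatter, so no order among the three can be read from these numbers. At the single concentration used, none of the three shows an effect that rises above the scatter.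

Compound 4 `COc1ccc(-c2cc(/C=C/C(=O)c3cc(OC)c(OC)c(OC)c3)[nH]n2)cc1OC` is not yet measured. It differs from compound 3 by hydrogen in place of methoxy on an aromatic carbon. Within the data shown here, this is the same kind of change as the one from compound 2 to compound 1, but not the same: in compound 3 the place is additionally meta to a methoxy group, which is absent at the place in compound 2.

The expectation for compound 4 rests on the earlier step, which was a number 2 percentage points lower from compound 2 to compound 1 (within the scatter), and on compound 3 giving 107% in this assay. The step from compound 3 to compound 4 in this assay is expected to be a number 2 percentage points lower from compound 3 to compound 4 (within the scatter), again within the scatter. Compound 4 is therefore estimated at 105%, with a likely range of 95% to 115%.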

Compound 4, a percentage reported as activity, at one concentration (the size of the read-out at that concentration, not a potency): 99%
Beside the measured number, compound 4's estimate is 6 percentage points above it; the range from low to high includes it.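

In this assay, hydrogen in place of methoxy on an aromatic carbon gives a number 8 percentage points lower from compound 3 to compound 4 (within the scatter). Set beside the same change on the other core, this step cannot be told apart from the earlier one: the same change on two cores in this assay, a number 2 percentage points lower (within the scatter) from compound 2 to compound 1 and a number 8 percentage points lower (within the scatter) from compound 3 to compound 4, 6 percentage points apart, within the scatter of two such steps So far, then, the change has produced no step beyond the scatter on either core, and the two cores give no sign of responding to it differently; this does not show that the change has a real effect of a shared size or direction, as neither step can be told from no change at all and each rests on a single concentration at which the series shows no effect above the scatter.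

Open, on these data alone, is whether a group other than hydrogen or methoxy at this place, such as a hydroxyl, a chlorine or a carboxylic acid, would give a step beyond the scatter on either core. Also open, as far as these compounds go, is whether the steps seen here would stay alike at other concentrations, where the compounds might show an effect that can be compared.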